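Butyl in place of benzoyl: notes on the series

This account rests on a few compounds, and the source may have more. Where it says the series, first, only, none or still open, it means among the compounds named here.

Compound 1 `Cc1ccccc1/C=C1\CN(C(=S)NC(=O)c2ccccc2)C/C(=C\c2ccccc2C)C1=O` is the starting point in a functional assay on HeLa cells (Homo sapiens) for antiproliferative activity, read by MTT assay, with a stated time of 48 h; on this read-out higher numbers stand for weaker inhibition and lower numbers for stronger inhibition. Compound 1 reads < 10000 nM, which is a limit of the assay and not a number. Compound 2 `Cc1ccc(/C=C2\CN(C(=S)NC(=O)c3ccccc3)C/C(=C\c3ccc(C)cc3)C2=O)cc1` reads < 10000 nM, which is also a limit. Neither compound has an exact position, so no step can be read between them.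

The next compound is compound 3 `CCCCNC(=S)N1C/C(=C\c2ccccc2C)C(=O)/C(=C/c2ccccc2C)C1`, which keeps the core of compound 1 and changes one group: butyl in place of benzoyl on an amide-type nitrogen.

Within the data shown here, no measured step covers this change, so its size in this assay can only be estimated. No shift beyond the usual scatter is expected, and neither direction is favoured. The only anchor for this expectation is compound 1 at < 10000 nM, again only a limit. The estimated change is a step that the limit leaves unreadable from compound 1 to compound 3. For compound 3 the expected value is 6000 nM, with an estimated range from 2000 nM to 15000 nM.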

Compound 3, half-maximal inhibitory concentration: < 10000 nM
Compound 3 ended at the assay's limit (the forecaster's own chance of this, stated with the estimate: 55%); the middle value is on the limit's open side.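

No step can be read from compound 1 to compound 3, because both values are limits of the assay and not numbers: the limit of < 10000 nM in this assay, at which 3 of the 3 values shown sit.

The compounds shown leave open where any of the three actually stands, and whether butyl in place of benzoyl on the amide-type nitrogen shifts the read-out at all.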